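Aryl amide variation on the carbonyl carbon of the series

The source may hold more compounds than are shown below. What is called first, only, known or untested is meant among the compounds shown, and "the series" means these compounds.

Compound 1 `CC(=O)NCCC1CCN(S(=O)(=O)NC(=O)NC[C@@H]2C[C@@H]3C=C[C@@H]2C3)CC1` and compound 2 `O=C(NC[C@@H]1C[C@@H]2C=C[C@@H]1C2)NS(=O)(=O)N1CCC(CCNC(=O)c2nc3ccccc3s2)CC1` share one core and differ only at the amide end. In a functional assay on the whole organism (blood) with Rattus norvegicus as the target, with stated times of 24 h and 1 h, at a dose of 5 mg/kg by the intraperitoneal route (a lower number here means a weaker effect, a higher number a stronger effect of the compound at the dose given), compound 1 gives 18% and compound 2 gives 24%. Compound 2 stands at the upper of the two numbers, but the gap, a number 6 percentage points higher from compound 1 to compound 2 (within the scatter), does not separate the pair. Compound 3 `COc1ccc2nccc(C(=O)NCCC3CCN(S(=O)(=O)NC(=O)NC[C@@H]4C[C@@H]5C=C[C@@H]4C5)CC3)c2c1` varies the same place again: 6-methoxyquinolin-4-yl in place of 1,3-benzothiazol-2-yl on a carbonyl carbon. Among the compounds with values here, the one measured step that bears on this place is a number 6 percentage points higher from compound 1 to compound 2 (within the scatter), a change of the same kind that stayed small, and nothing measured tells how 6-methoxyquinolin-4-yl compares with 1,3-benzothiazol-2-yl. The step expected from this change is therefore small, a number 1 percentage points higher from compound 2 to compound 3 (within the scatter), with no direction beyond the scatter. Compound 3 is estimated at 25% in this assay, with a range from 10% to 42%.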

Compound 3, a percentage reported as activity, at one dose (the size of the read-out at that dose, not a potency): 10%
Beside the measured number, compound 3's estimate is 15 percentage points above it; measured number inside the range.
By their numbers in this assay, from the lowest: compounds 3, 1 and 2 (each within the scatter of the next, the first and the last beyond it).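

In this assay, this carbonyl carbon now gives a step beyond the scatter: a number 14 percentage points lower from compound 2 to compound 3 (beyond the scatter), so 6-methoxyquinolin-4-yl and 1,3-benzothiazol-2-yl are not interchangeable at this place. Within the data shown here, the step from methyl stays small, at a number 8 percentage points lower from compound 1 to compound 3 (within the scatter), so compound 1 cannot be separated from compound 3 here, just as it could not be separated from compound 2, and only the pair of larger aromatic groups is told apart. Nothing available gives a cause for the step between them.

The compounds shown leave open whether the methoxy group has any part in the step, which plain quinolin-4-yl would address. They also leave open how this position responds to a group of another kind, such as an aminomethyl group, a carboxylic acid or a longer alkyl chain on the carbonyl carbon.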